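The compounds below may be only part of what the source reports. "The series", "measured", "known", "first", "only" and "open" are said of these compounds alone.

In a functional assay on HCT-116 cells (Homo sapiens) for antiproliferative activity, read by MTT assay, with a stated time of 72 h (a lower number here means a stronger inhibitor, a higher number a weaker inhibitor), compound 2 (`Cc1noc(C)c1-c1nn(Cc2ccc(C(=O)NC3CCN(C)CC3)cc2)c(=O)c2ccccc12`) gives 84900 nM. That lies within the usual scatter of compound 1 (`CN1CCC(NC(=O)c2ccc(Cn3nc(-c4cnn(C)c4)c4ccccc4c3=O)cc2)CC1`) at 69500 nM, while compound 3 (`CC(=O)Nc1ccc(Sc2nc(Nc3cc(C)[nH]n3)cc(N3CCN(C)CC3)n2)cc1`), a differently built molecule, gives a clearly lower 10100 nM. Compound 4 (`Cc1noc(C)c1-c1nn(Cc2ccc(C(=O)NC3CCCCC3)cc2)c(=O)c2ccccc12`) keeps the rest of compound 2 but has cyclohexyl in place of 1-methylpiperidin-4-yl on an amide-type nitrogen. For the measured compounds named here, the only measured step, a 1.2-fold higher number from compound 1 to compound 2 (0.09 log units; within the scatter), lies within the scatter and concerns a different group, so it offers weak guidance. Going by the values given here, no measured pair tests this swap, so no step beyond the scatter is expected, though with wide uncertainty. The expected step is a 1.4-fold lower number from compound 2 to compound 4 (0.15 log units; within the scatter). For compound 4 the estimated value is 60000 nM, with an expected range of 20000 nM to 150000 nM.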

Compound 4, half-maximal inhibitory concentration: > 100000 nM
Compound 4 was reported as a limit; the forecaster's own chance of this, stated with the estimate: 25%; at least 1.6-fold (0.22 log units) between middle value and limit.
By their numbers in this assay, from the lowest: compound 3; then compounds 1 and 2 (each within the scatter of the next). At a limit, above all of these: compound 4.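

In this assay compound 4 is reported only as a limit, > 100000 nM. For the compounds shown here, this is the first change tested on the amide-type nitrogen: cyclohexyl in place of 1-methylpiperidin-4-yl gives an at least 1.1-fold higher number from compound 2 to compound 4 (0.07 log units; that floor lies within the scatter), so the size of the true step cannot be read, and nothing here shows cyclohexyl lowering the number. The result sits at the edge of what this series reports: the limit of > 100000 nM in this assay, at which 1 of the 4 values shown sits.

As far as these compounds go, whether a smaller group on this nitrogen, such as a primary amine on a short ethyl chain, or a carboxylic acid on the same chain, would lower the number remains open. So does how far past its limit compound 4 truly lies.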